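This account rests on a few compounds, and the source may have more. Where it says the series, first, only, none or still open, it means among the compounds named here.

The measured compounds:

Compound 1, `COc1cccc(CNCCCNc2ccnc3cc(Cc4ccccc4)ccc23)c1O`, in a physicochemical assay for acid dissociation, gives 9.47.
Compound 2, `COc1ccc(F)cc1CNCCCNc1ccnc2cc(-c3ccc(F)cc3)ccc12`, in this assay gives 9.47.

Compound 2 stands level with compound 1 at the digits recorded; the two values lie within the usual scatter of each other, so no difference between them can be claimed. Compound 3, `COc1ccc(F)cc1CNCCCNc1ccnc2cc(Cc3ccccc3)ccc12`, has not yet been measured. It differs from compound 2 in one place: benzyl in place of 4-fluorophenyl on an aromatic carbon. This exchange sits on the fused ring system, away from the amine part shared by all three compounds. Compound 1 already carries the benzyl group at this position and compound 2 the 4-fluorophenyl, and their values match, so no step beyond the scatter is expected; the step from compound 2 to compound 3 is expected to be no change at the digits printed from compound 2 to compound 3 (within the scatter). For compound 3 the expected value in this assay is 9.47, within a range from 9.15 to 9.8.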

Compound 3, acid dissociation constant: 9.47
Estimate against measurement, compound 3: no gap at the digits printed; measured number inside the range.
By their numbers in this assay, from the lowest: compounds 1, 2 and 3 (each within the scatter of the next).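

In this assay, the exchange of 4-fluorophenyl for benzyl on an aromatic carbon gives no change at the digits printed from compound 2 to compound 3 (within the scatter), so this position now has a comparison in which only one place differs. The exchange of 2-hydroxy-3-methoxyphenyl for 5-fluoro-2-methoxyphenyl on a saturated chain carbon bound to an amine nitrogen gives no change at the digits printed from compound 1 to compound 3 (within the scatter), which isolates the second place of difference and shows that this exchange, too, stays within the scatter. Nothing further is available to explain these results.

Both groups at the aromatic position contain one six-membered aromatic ring of carbon only, so the compounds shown leave open how this assay would respond to a carboxylic acid or an amine there. A longer chain at that position also remains an open case.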